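This account rests on a few compounds, and the source may have more. Where it says the series, first, only, none or still open, it means among the compounds named here.

Measured so far in a functional assay on DLD-1 cells (Homo sapiens) for cytotoxicity, read by MTT assay; a lower number here means a stronger inhibitor, a higher number a weaker inhibitor:
- compound 1 `COc1cc(/C=C/C(=O)C(=Cc2ccc(O)cc2)C(=O)/C=C/c2ccc(O)c(OC)c2)ccc1O`: 4080 nM
- compound 2 `CCOc1cc(/C=C/C(=O)C(=Cc2ccc(OC)c(OC)c2)C(=O)/C=C/c2ccc(O)c(OCC)c2)ccc1O`: 42000 nM

Compound 2 stands highest of the two numbers, and the gap down to compound 1 lies beyond the scatter. It is therefore the weaker inhibitor of the pair.

The next compound to be read is compound 3 `CCOc1cc(/C=C/C(=O)C(=Cc2ccccc2)C(=O)/C=C/c2ccc(O)c(OCC)c2)ccc1O`, which has phenyl in place of 3,4-dimethoxyphenyl on a double-bonded chain carbon bound to a double-bonded chain carbon. The counted difference is phenyl in place of 3,4-dimethoxyphenyl on a double-bonded chain carbon bound to a double-bonded chain carbon and the rest of the structure is unchanged.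

Among the compounds with values here, no measured step isolates this change, so any expectation is tentative. It rests on the two values alone: compound 2 at 42000 nM sits at the top of the pair, while compound 1 at 4080 nM shows that this series can reach lower numbers. A move toward a lower number therefore seems more likely than a further rise.

The estimated size is a 3.5-fold lower number from compound 2 to compound 3 (0.54 log units; beyond the scatter) in the direction of a lower number, expected to lie beyond the scatter.

For compound 3 the expected value is 12000 nM as a middle estimate, with an expected range of 3000 nM to 45000 nM around it.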

Compound 3, half-maximal inhibitory concentration: 5060 nM
For compound 3 the middle estimate is 2.4-fold (0.38 log units) above the measured one; measured number inside the range.
By their numbers in this assay, from the lowest: compounds 1 and 3 (each within the scatter of the next); then compound 2.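

Within the data shown here, on the double-bonded chain carbon bound to a double-bonded chain carbon, phenyl in place of 3,4-dimethoxyphenyl gives, in this assay, an 8.3-fold lower number from compound 2 to compound 3 (0.92 log units; beyond the scatter), the first single-place comparison. This position is therefore not silent: the group there alters the reading with the rest of the structure held constant, and the bare phenyl, with 0 hydrogen-bond acceptors against 2 in the group it replaces, is the better of the two groups compared here. Nothing available bears on why the reading moves in this direction.

This single step cannot tell whether both methoxy groups count against activity or only one, since they leave together, and compound 1 differs from compound 3 in more than one place, so it does not settle the matter. Also open, going by these compounds, is how the position responds to a phenyl carrying a single methoxy group, a chlorine or a dimethylamino group, each of which would show whether the bare phenyl is a limit or merely one point on a wider range.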